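The source may report more compounds than this note shows. Statements on the series, on what has been measured and on what is new or still open speak of the compounds shown alone.

Measured compounds:
compound 1, `COc1ccc(C2=NN(C3=NC(c4ccccc4)CS3)C(c3cccc4ccccc34)C2)cc1`, 3310 nM
compound 2, `Fc1ccc(C2=NN(C3=NC(c4ccccc4)CS3)C(c3cccc4ccccc34)C2)cc1`, 12400 nM
compound 3, `Fc1ccc(C2=NN(C3=NC(c4ccccc4)CS3)C(c3ccc4ccccc4c3)C2)cc1`, 9730 nM

All three were tested in a functional assay on HeLa cells (Homo sapiens) for inhibition, read by CCK-8 assay, with a stated time of 48 h; on this read-out lower numbers stand for stronger inhibition and higher numbers for weaker inhibition. Among the three numbers compound 3 stands second highest. Its nearest neighbour is compound 2, and the step of a 1.3-fold lower number from compound 2 to compound 3 (0.11 log units; within the scatter) lies within the scatter, so the two cannot be told apart. Among the compounds with values here, compound 1 stands furthest off, with a lower number that lies beyond the scatter; no single-point step links compound 1 and compound 3, so only the two values themselves can be compared.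

Compound 4, `c1ccc(C2=NN(C3=NC(c4ccccc4)CS3)C(c3ccc4ccccc4c3)C2)cc1`, differs from compound 3 by hydrogen in place of fluoro on an aromatic carbon. Within the data shown here, the only measured step touching that aromatic carbon is a 3.7-fold higher number from compound 1 to compound 2 (0.57 log units; beyond the scatter), where fluoro replaced methoxy; it raised the number modestly. Among the measured compounds shown here, no measured step shows hydrogen in that position, so the size of the step from fluoro to hydrogen is not fixed by the data. Given that the one comparison at this carbon stayed modest, the step to compound 4 is expected to be small, at most a slight lowering of the number, with a 1.2-fold lower number from compound 3 to compound 4 (0.09 log units; within the scatter) as the estimate. Compound 4 is therefore expected to give 8000 nM in this assay, within a range from 3000 nM to 25000 nM.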

Compound 4, half-maximal inhibitory concentration: 3860 nM
For compound 4 the middle estimate is 2.1-fold (0.32 log units) above the measured one; the range from low to high includes it.
By their numbers in this assay, from the lowest: compounds 1 and 4 (each within the scatter of the next); then compounds 3 and 2 (each within the scatter of the next).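

In this assay the change from 4-fluorophenyl to phenyl gives a 2.5-fold lower number from compound 3 to compound 4 (0.40 log units; beyond the scatter) and so lies beyond the scatter, showing that this aromatic carbon, para to a large group, responds to the simple loss of fluoro and not only to an exchange of fluoro with methoxy. Read together with a 3.7-fold higher number from compound 1 to compound 2 (0.57 log units; beyond the scatter) in the naphthalen-1-yl pair, it means that in both pairs differing at this carbon the fluoro compound carries the higher number, with methoxy in one pair and hydrogen in the other, and that fluoro is not needed for the inhibition seen in the naphthalen-2-yl pair. No measurement at hand accounts for this change in the number.

Going by these compounds, whether the change from fluoro to hydrogen would move the number in the same way with naphthalen-1-yl on the saturated ring carbon remains open. Also open, on these data alone, is how other groups on this aromatic carbon, such as chloro, an amine or a carboxylic acid, would compare with hydrogen on the same core.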